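Sulfonyl Aryl Swap on a Shared Indazolyl Core

The source may report more compounds than this note shows. Statements on the series, on what has been measured and on what is new or still open speak of the compounds shown alone.

Measured compounds in a functional assay on HCT-116 cells (Homo sapiens) for antiproliferative activity, read by MTT assay, with a stated time of 72 h; a higher number here means a weaker inhibitor, a lower number a stronger inhibitor:
Compound 1 `CN(C(=O)c1ccc(Br)cc1)c1ccc2[nH]c(-c3n[nH]c4ccccc34)cc2n1` gives 6110 nM.
Compound 2 `CN(C(=O)c1ccco1)c1ccc2[nH]c(-c3n[nH]c4ccccc34)cc2n1` gives 30000 nM.
Compound 3 `Cc1ccc(S(=O)(=O)N(C)c2ccc3[nH]c(-c4n[nH]c5ccccc45)cc3n2)cc1` gives 13300 nM.

Compound 3 stands second highest of the three numbers in this assay . Its nearest neighbour is compound 1, reached by the step of a 2.2-fold higher number from compound 1 to compound 3 (0.34 log units; beyond the scatter); compound 2 lies furthest away, as shown by the step of a 2.3-fold lower number from compound 2 to compound 3 (0.35 log units; beyond the scatter). For the measured compounds named here, the only other measured step, a 4.9-fold higher number from compound 1 to compound 2 (0.69 log units; beyond the scatter), also changes the group attached to the carbonyl or sulfonyl.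

Compound 4 `CN(c1ccc2[nH]c(-c3n[nH]c4ccccc34)cc2n1)S(=O)(=O)c1cccc([N+](=O)[O-])c1` differs from compound 3 in one place: 3-nitrophenyl in place of 4-methylphenyl on a sulfonyl sulfur. None of the three measured steps changes a substituent on the aryl ring of a sulfonyl; each instead exchanges the whole acyl or sulfonyl group. The measured steps therefore give no direct guide, and all of them were modest in size.

With that, compound 4 is expected to stay close to compound 3, with an estimated step of a 1.0-fold lower number from compound 3 to compound 4 (0.01 log units; within the scatter). For compound 4 the estimate in this assay is 13000 nM, with a range from 4500 nM to 40000 nM.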

Compound 4, half-maximal inhibitory concentration: 13600 nM
For compound 4 the middle estimate is 1.0-fold (0.02 log units) below the measured one; the range from low to high includes it.
By their numbers in this assay, from the lowest: compound 1; then compounds 3 and 4 (each within the scatter of the next); then compound 2.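

In this assay, for the compounds shown here, the exchange on the sulfonyl sulfur gives a 1.0-fold higher number from compound 3 to compound 4 (0.01 log units; within the scatter), the first measured step that keeps the sulfonyl and changes only the aryl group on it. The earlier steps shown here each exchanged the whole carbonyl or sulfonyl group, whereas this one shows that 4-methylphenyl and 3-nitrophenyl, which differ in heavy atoms and hydrogen-bond acceptors, give numbers within the scatter of each other at this place. No measurement shown accounts for this result.

As far as these compounds go, it remains open whether a phenyl ring carrying an amine or a carboxylic acid on this sulfonyl would also stay within the scatter of compound 3, or whether a longer alkyl chain could replace the ring. Also open, from the compounds shown here alone, is whether any sulfonyl group at this nitrogen could match compound 1 at 6110 nM.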